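Changing the pyrrole attachment on the carbonyl carbon

The source may report more compounds than this note shows. Statements on the series, on what has been measured and on what is new or still open speak of the compounds shown alone.

Compound 1 `C#CCOc1ccc(/C=C/C(=O)c2cccn2C)cc1OC` was examined in a functional assay on CCRF-CEM cells (Homo sapiens) for cytotoxicity, with a stated time of 72 h; on this read-out lower numbers stand for stronger inhibition and higher numbers for weaker inhibition. In this assay compound 1 gives > 50000 nM, which is a limit of the assay and not a number. Compound 2 `C=CCOc1ccc(/C=C\C(=O)c2ccc(OCC=C(C)C)c(CC=C)c2)cc1OC` is the only other measured entry. In this assay compound 2 gives > 50000 nM, again a limit of the assay. Both results sit at the same limit (the limit of > 50000 nM in this assay, at which 2 of the 2 values shown sit), so compound 1 stands at the limit and no number separates it from compound 2. Compound 3 `C#CCOc1ccc(/C=C/C(=O)c2ccn(C)c2)cc1OC` has not yet been measured. It differs from compound 1 in one place: 1-methyl-1H-pyrrol-3-yl in place of 1-methyl-1H-pyrrol-2-yl on a carbonyl carbon. Within the data shown here, no step between measured compounds is available, so the size of this change cannot be read from the data. The step that the limit leaves unreadable from compound 1 to compound 3 is expected to stay within the scatter, since compound 1 itself reaches only the limit. Compound 3 is therefore estimated at 60000 nM, between 20000 nM and 200000 nM.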

Compound 3, half-maximal inhibitory concentration: > 50000 nM
Compound 3: no number, only a limit; the forecaster's own chance of this, stated with the estimate: 85%; the middle value does not contradict the limit.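

The step from compound 1 to compound 3 cannot be read, because both compounds stop at a limit of the assay and not at a number: the limit of > 50000 nM in this assay, at which 3 of the 3 values shown sit. The compounds shown leave open whether 1-methyl-1H-pyrrol-3-yl in place of 1-methyl-1H-pyrrol-2-yl on a carbonyl carbon makes any difference to cytotoxicity.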